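Ester in place of the aminoethyl amide on compound 2

The source may report more compounds than this note shows. Statements on the series, on what has been measured and on what is new or still open speak of the compounds shown alone.

Measured so far:
compound 1 `C#CCCOC(=O)c1ccc(C(CC)(CC)c2ccc(OCC(=O)C(C)(C)C)c(C)c2)n1CC`: 28800 nM
compound 2 `CCn1c(C(=O)NCCN)ccc1C(CC)(CC)c1ccc(OCC(O)C(C)(C)C)c(C)c1`: 10 nM

In an assay on HL-60 cells for agonist activity at vitamin D3 receptor (Homo sapiens), read by microscopy, with a stated time of 96 h (on this read-out lower numbers stand for an effect already at smaller amounts and higher numbers for an effect only at larger amounts of compound), compound 2 gives 10 nM, the lower of the two measured numbers. For the measured compounds named here, compound 1 gives 28800 nM, far above it and beyond the scatter; no single-change step links these two, so their values are only compared side by side. Compound 3 `C#CCCOC(=O)c1ccc(C(CC)(CC)c2ccc(OCC(O)C(C)(C)C)c(C)c2)n1CC` is unmeasured and differs from compound 2 in one place: (but-3-yn-1-yl)oxy in place of (2-aminoethyl)amino on a carbonyl carbon. The step from compound 2 to compound 3 is expected to be upward and beyond the scatter, estimated as a 150-fold higher number from compound 2 to compound 3 (2.18 log units; beyond the scatter), given that compound 1, also an ester, stands at 28800 nM. Compound 3 is estimated at 1500 nM, within 100 nM to 20000 nM.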

Compound 3, half-maximal effective concentration: 1030 nM
Estimate against measurement, compound 3: 1.5-fold (0.16 log units) above, within the range that was stated.
By their numbers in this assay, from the lowest: compound 2; then compound 3; then compound 1.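

In this assay, the carbonyl position now has a single-change reading: (but-3-yn-1-yl)oxy in place of (2-aminoethyl)amino gives a 100-fold higher number from compound 2 to compound 3 (2.01 log units; beyond the scatter), so the ester stands well behind the amide. The other arm also matters on its own: 1-hydroxy-2,2-dimethylpropyl in place of (tert-butyl)carbonyl gives a 28-fold lower number from compound 1 to compound 3 (1.45 log units; beyond the scatter), so the wide gap between compound 1 and compound 2 spans two separate changes. No supporting data explain either step. Open, as far as these compounds go, is whether a carboxylic acid or a longer aminoalkyl chain on that carbonyl carbon would match compound 2.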